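This account rests on a few compounds, and the source may have more. Where it says the series, first, only, none or still open, it means among the compounds named here.

In a functional assay on the whole organism (strain Wistar) with Rattus norvegicus as the target, with a stated time of 15 days, at a dose of 10 mg/kg by the oral route (a higher number here means a stronger effect of the compound at the dose given, a lower number a weaker effect), the three measured compounds give these numbers:

Compound 1 `Cc1nc(COc2ccc(/C=C3\SC(=O)NC3=O)cc2)cs1` gives 19.2%.
Compound 2 `O=C1NC(=O)/C(=C/c2ccc(OCCSc3nnc(Cc4ccccc4)[nH]3)cc2)S1` gives 22.8%.
Compound 3 `O=C1NC(=O)/C(=C/c2ccc(OCCSc3nnc(-c4ccc([N+](=O)[O-])cc4)[nH]3)cc2)S1` gives 15.3%.

Compound 3 sits at the low end of these three numbers, yet its gap to compound 1 and its gap to compound 2 both lie within the scatter, so the three cannot be told apart. Compound 4 `O=C1NC(=O)/C(=C/c2ccc(OCCSc3nnc(-c4ccc(Br)cc4)[nH]3)cc2)S1` differs from compound 3 by bromo in place of nitro on an aromatic carbon. Within the data shown here, the only measured step, a number 7.5 percentage points lower from compound 2 to compound 3 (within the scatter), swapped a different group and stayed within the scatter; no step on a bromo for nitro exchange exists. A change of no more than the scatter is therefore expected, a number 2.7 percentage points higher from compound 3 to compound 4 (within the scatter). Compound 4 is estimated at 18%, within 8% to 30%.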

Compound 4, a percentage reported as activity, at one dose (the size of the read-out at that dose, not a potency): 26.9%
The estimate for compound 4 lay 8.9 percentage points below the measured number; the measured number falls inside the stated range.
By their numbers in this assay, from the lowest: compounds 3, 1, 2 and 4 (each within the scatter of the next, the first and the last beyond it).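

In this assay, among these compounds, bromo in place of nitro on the aromatic carbon para to a large group gives a number 11.6 percentage points higher from compound 3 to compound 4 (beyond the scatter), the only step here beyond the scatter, so what sits at this position can shift the read-out. Set against the benzyl compound, the 4-bromophenyl group gives a number 4.1 percentage points higher from compound 2 to compound 4 (within the scatter), a gap too small to separate the two. Nothing available explains why bromo and nitro differ.

Open, from the compounds shown here alone, is where other groups at this position, such as an amine or a carboxylic acid, fall relative to bromo and nitro. Going by these compounds, whether the bromo gain holds at other doses also remains unknown.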